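Hydroxy for cyano at the terminal aryl ring of compound 3

A few compounds are considered here, and "the series" means these few. Any claim that something is new, unique, unknown or untested is made for them only; others in the source may bear on it.

Compound 3 `COc1cc2ncnc(Nc3ccc(F)c(Cl)c3)c2cc1NC(=O)N/N=C/c1ccc(C#N)cc1` gives 34100 nM in a functional assay on HepG2 cells (Homo sapiens) for cytotoxicity, read by MTT assay, with a stated time of 72 h (on this read-out lower numbers stand for stronger inhibition and higher numbers for weaker inhibition), the highest number among the three measured compounds. Among the measured compounds shown here, compound 1 `N#Cc1ccc(/C=N/NC(=O)Nc2cc3c(Nc4ccc(F)c(Cl)c4)ncnc3cc2O[C@H]2CCOC2)cc1` gives 26400 nM in this assay; the step of a 1.3-fold higher number from compound 1 to compound 3 (0.11 log units; within the scatter) is the only measured change at the ether on the shared core and does not separate the two. Compound 2 `O=C(N/N=C/c1cc(Br)c(O)c(Br)c1)Nc1cc2c(Nc3ccc(F)c(Cl)c3)ncnc2cc1O[C@H]1CCOC1` gives 2740 nM in this assay, the lowest number of the set.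

Compound 4 `COc1cc2ncnc(Nc3ccc(F)c(Cl)c3)c2cc1NC(=O)N/N=C/c1ccc(O)cc1` differs from compound 3 by hydroxy in place of cyano on an aromatic carbon. For the measured compounds named here, the only measured step that touches this ring is a 9.6-fold lower number from compound 1 to compound 2 (0.98 log units; beyond the scatter), where a hydroxy also enters on that ring, but together with two bromines, so its size cannot be assigned to the hydroxy alone. The change at the ether, a 1.3-fold higher number from compound 1 to compound 3 (0.11 log units; within the scatter), does not bear on the aryl ring. On this basis a lowering of the number from compound 3 to compound 4 is expected, smaller than the dibromo-hydroxy step and not certain to clear the scatter, estimated as a 2.3-fold lower number from compound 3 to compound 4 (0.36 log units; beyond the scatter). Compound 4 is therefore expected to give about 15000 nM in this assay, with a range from 5000 nM to 40000 nM.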

Compound 4, half-maximal inhibitory concentration: 26300 nM
Compound 4: the middle estimate sits 1.8-fold (0.24 log units) below what was measured; the measured number falls inside the stated range.
By their numbers in this assay, from the lowest: compound 2; then compounds 4, 1 and 3 (each within the scatter of the next).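

In this assay, among the compounds shown here, the change from 4-cyanophenyl to 4-hydroxyphenyl on the methyl ether gives a 1.3-fold lower number from compound 3 to compound 4 (0.11 log units; within the scatter), so hydroxy in place of cyano, para to a large group, is the first single-group change at this ring position and leaves compounds 3 and 4 within the scatter of each other. This isolates the hydroxy, which the earlier ring step could not do: a 9.6-fold lower number from compound 1 to compound 2 (0.98 log units; beyond the scatter) lies beyond the scatter, but there the hydroxy entered together with two bromines, and on the oxolan-3-yl ether. The ether difference itself, a 1.3-fold higher number from compound 1 to compound 3 (0.11 log units; within the scatter), lies within the scatter, so among the compounds shown, hydroxy alone does not reproduce the larger step, and the bromines remain the unseparated part of that change.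

As far as these compounds go, it remains open how much of the step to compound 2 belongs to the two bromines, and whether an amine or a carboxylic acid at this same place would also stay within the scatter of compounds 3 and 4. No measurement is available that explains why cyano and hydroxy give numbers within the scatter of each other here.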